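The source may report more compounds than this note shows. Statements on the series, on what has been measured and on what is new or still open speak of the compounds shown alone.

Measured so far in a physicochemical assay for solubility, read by HPLC, in simulated intestinal fluid, with a stated time of 16 h, tested at 125 ug/mL; on this read-out lower numbers stand for lower solubility and higher numbers for higher solubility:
compound 1 `CNC(=O)c1cc(C(=O)NC2CC2)cn(Cc2ccc(OC)cc2)c1=O`: 263 ug/mL
compound 2 `CNC(=O)c1cc(C(=O)NC2CC2)cn(Cc2ccc(C)cc2)c1=O`: 11 ug/mL
compound 3 `CNC(=O)c1cc(C(=O)NC2CC2)cn(Cc2cccc3[nH]ccc23)c1=O`: 17 ug/mL

Compound 1 stands highest of the three numbers in this assay. Its two neighbours lie well apart from it: a 24-fold lower number from compound 1 to compound 2 (1.38 log units; beyond the scatter) and a 15-fold lower number from compound 1 to compound 3 (1.19 log units; beyond the scatter). Between the two lower compounds the gap is small, a 1.5-fold higher number from compound 2 to compound 3 (0.19 log units; within the scatter).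

Compound 4 `CNC(=O)c1cc(C(=O)NC2CC2)cn(Cc2cccc3cn[nH]c23)c1=O` has not yet been measured. It differs from compound 1 in one place: 1H-indazol-7-yl in place of 4-methoxyphenyl on a saturated chain carbon bound to an aromatic nitrogen. Within the data shown here, the step that bears most closely on this change is the one from compound 1 to compound 3, since there too the 4-methoxyphenyl on the saturated chain carbon bound to an aromatic nitrogen gave way to a two-ring group carrying one hydrogen-bond donor, and the number fell by a 15-fold lower number from compound 1 to compound 3 (1.19 log units; beyond the scatter). The step from compound 1 to compound 2 shows that even a small change on that same aromatic ring moved the number a long way downward. A large drop in this assay is therefore expected for compound 4, of roughly the size seen for compound 3. Compound 4 is expected to give about 20 ug/mL, within a range of 6 ug/mL to 65 ug/mL. That estimate corresponds to an expected step of a 13-fold lower number from compound 1 to compound 4 (1.12 log units; beyond the scatter).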

Compound 4, solubility: 131 ug/mL
Compound 4: the middle estimate sits 6.6-fold (0.82 log units) below what was measured; measured number above the stated range.
By their numbers in this assay, from the lowest: compounds 2 and 3 (each within the scatter of the next); then compounds 4 and 1 (each within the scatter of the next).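

Replacing 4-methoxyphenyl with 1H-indazol-7-yl at this place, on a saturated chain carbon bound to an aromatic nitrogen, gives a result in this assay that cannot be told apart from compound 1 (a 2.0-fold lower number from compound 1 to compound 4 (0.30 log units; within the scatter)), so a two-ring group here need not bring the low numbers of compound 3. The particular group matters: 1H-indazol-7-yl in place of 1H-indol-4-yl gives (a 7.7-fold higher number from compound 3 to compound 4 (0.89 log units; beyond the scatter)), and in place of 4-methylphenyl it gives (a 12-fold higher number from compound 2 to compound 4 (1.08 log units; beyond the scatter)). No measurement shown here accounts for these differences.

The names show that 1H-indol-4-yl and 1H-indazol-7-yl differ both in their ring atoms and in their point of attachment, and the compounds shown cannot separate those two changes. Also open, on these data alone, is how an amine or a carboxylic acid would fare at this same place.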